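Adding a Methyl to the Core of Compound 1

The source may hold more compounds than are shown below. What is called first, only, known or untested is meant among the compounds shown, and "the series" means these compounds.

Compound 1, `Cc1cccnc1-c1ccc(C(=O)Nc2ccc(C(F)(F)F)cc2)cc1`, was tested in a functional assay for antagonist activity at transient receptor potential cation channel subfamily V member 1 (Rattus norvegicus) (on this read-out higher numbers stand for weaker inhibition and lower numbers for stronger inhibition), and in that test compound 1 gives 81 nM. Compound 3, `CC(C)(C)c1ccc(NC(=O)c2ccc(-c3ncccc3-c3nnco3)cc2)cc1`, is built on a different core; the difference between the two cores is not broken down here. In this assay compound 3 gives 59 nM, while compound 2, `Cc1nnc(-c2cccnc2-c2ccc(C(=O)Nc3ccc(C(C)(C)C)cc3)cc2)o1`, gives 34 nM. Compound 2 differs from compound 3 in one place only, (methyl in place of hydrogen on an aromatic carbon), on an aromatic carbon of a five-membered aromatic ring with 2 nitrogen and 1 oxygen, next to the ring nitrogen and next to the ring oxygen. That change produced a 1.7-fold lower number from compound 3 to compound 2 (0.24 log units; within the scatter).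

Compound 4, `Cc1cc(-c2ncccc2C)ccc1C(=O)Nc1ccc(C(F)(F)F)cc1`, has not been measured yet. It comes from compound 1 through (methyl in place of hydrogen on an aromatic carbon). Within the data shown here, this is the same kind of change as the one from compound 3 to compound 2, but not the same: here the methyl enters on an aromatic carbon of a six-membered aromatic ring of carbon only, ortho to a large group and meta to a 3-methylpyridin-2-yl group, rather than on the five-membered ring. Among the measured compounds shown here, only one such step has been measured, so the expectation rests on it alone. Because a 1.7-fold lower number from compound 3 to compound 2 (0.24 log units; within the scatter) stayed within the usual scatter, a similarly modest step is expected from compound 1 to compound 4, namely a 1.2-fold lower number from compound 1 to compound 4 (0.10 log units; within the scatter). For compound 4 the estimated value in this assay is 65 nM, expected to lie between 25 nM and 170 nM.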

Compound 4, half-maximal inhibitory concentration: > 4000 nM
Compound 4: only a limit was reported; the forecaster's own chance of this, stated with the estimate: 3%; at least 61-fold (1.78 log units) between middle value and limit.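

In this assay compound 4 gives > 4000 nM, which is a limit of the assay and not a number. Adding this methyl brings an at least 49-fold higher number from compound 1 to compound 4 (1.69 log units; beyond the scatter), so the same kind of change, methyl in place of hydrogen on an aromatic carbon, does not behave alike on the two cores: the same change on two cores in this assay, a 1.7-fold lower number (0.24 log units; within the scatter) from compound 3 to compound 2 and an at least 49-fold higher number (1.69 log units; beyond the scatter) from compound 1 to compound 4, at least 85-fold (1.93 log units) apart, beyond the scatter of two such steps This shows that the name of a change is a poor guide on its own when it moves to another core in this series, but it does not show what lies behind the difference: the methyl enters a five-membered aromatic ring in compound 2 and a six-membered aromatic ring of carbon only in compound 4, the two pairs also differ in their cores, and one pair on each core cannot pull these apart.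

As far as these compounds go, it remains open whether the loss in compound 4 is tied to the methyl itself or would also follow from a fluorine, a chlorine or a methoxy group at the same place, ortho to a large group. Also open, from the compounds shown here alone, is what the same methyl would do at that place on the core of compound 3.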